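The compounds below may be only part of what the source reports. "The series", "measured", "known", "first", "only" and "open" are said of these compounds alone.

Measured so far in a functional assay on HCT-116 cells (Homo sapiens) for cytotoxicity, read by MTT assay, with a stated time of 48 h; a lower number here means a stronger inhibitor, a higher number a weaker inhibitor:
compound 1 `Cc1nc2c3ccccc3ccc2c2nc3c(ccc4ccccc43)c(-c3cc([N+](=O)[O-])ccc3N)c12` — 6010 nM
compound 2 `Cc1nc2c3ccccc3ccc2c2nc3c(ccc4ccccc43)c(-c3ccccc3N)c12` — 4760 nM
compound 3 `Cc1nc2c3ccccc3ccc2c2nc3c(ccc4ccccc43)c(-c3ccccc3Cl)c12` — 48200 nM

Compound 1 holds the second highest of the three numbers in this assay; its nearest neighbour is compound 2, with a 1.3-fold lower number from compound 1 to compound 2 (0.10 log units; within the scatter), and its furthest is compound 3, with an 8.0-fold higher number from compound 1 to compound 3 (0.90 log units; beyond the scatter).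

Compound 4 `Cc1nc2c3ccccc3ccc2c2nc3c(ccc4ccccc43)c(-c3cc(O)nc4ccccc34)c12` is the next step from compound 1: 2-hydroxyquinolin-4-yl in place of 2-amino-5-nitrophenyl on an aromatic carbon. Within the data shown here, the steps that bear on it are the two aryl swaps onto the same carbon of the shared core, an 8.0-fold higher number from compound 1 to compound 3 (0.90 log units; beyond the scatter) and a 10-fold higher number from compound 2 to compound 3 (1.01 log units; beyond the scatter), both moving the number up. Neither introduces a 2-hydroxyquinolin-4-yl group, so the direction is uncertain; the entering group keeps one hydrogen-bond donor, as does the leaving group, which argues for a smaller shift than with compound 3. Compound 4 is therefore expected to give 9000 nM (3000 nM to 30000 nM), meaning an expected 1.5-fold higher number from compound 1 to compound 4 (0.18 log units; within the scatter).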

Compound 4, half-maximal inhibitory concentration: 4630 nM
Compound 4: middle estimate off by 1.9-fold (0.29 log units), on the high side; the measured number falls inside the stated range.
By their numbers in this assay, from the lowest: compounds 4, 2 and 1 (each within the scatter of the next); then compound 3.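

In this assay, this aromatic carbon of the shared core carries 2-hydroxyquinolin-4-yl at a number within the scatter of both amino-bearing aryl compounds (a 1.3-fold lower number from compound 1 to compound 4 (0.11 log units; within the scatter)) and (a 1.0-fold lower number from compound 2 to compound 4 (0.01 log units; within the scatter)). An amino group on the aryl ring is therefore not needed to match them, and the 2-chlorophenyl of compound 3 alone stands apart (a 10-fold lower number from compound 3 to compound 4 (1.02 log units; beyond the scatter)). Nothing measured here explains these results.

Still open, going by these compounds, is what the hydroxy group of 2-hydroxyquinolin-4-yl contributes. Plain quinolin-4-yl or a methoxy in its place would test this.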